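This account rests on a few compounds, and the source may have more. Where it says the series, first, only, none or still open, it means among the compounds named here.

Compound 1 `C1CCCC2(CC1)OOC1(CCCCCC1)OO2` gives > 100 ug/mL as a limit
Compound 2 `CS(=O)(=O)N1CCC2(CC1)OOC1(CCCC1)OO2` gives > 100 ug/mL as a limit
Compound 3 `CS(=O)(=O)N1CCC2(CC1)OOC1(CCCCC1)OO2` gives > 100 ug/mL as a limit

All three compounds were tested in a functional assay on Huh-7 cells (Homo sapiens) for cytotoxicity, read by MTT assay, with a stated time of 72 h (on this read-out higher numbers stand for lower toxicity in this test and lower numbers for higher toxicity in this test), and none of them returned an actual number. The whole set comes down to the limit of > 100 ug/mL in this assay, at which 3 of the 3 values shown sit, and nothing more. Compound 3 therefore stands with the other two, and its > 100 ug/mL is a limit of the assay and not a number.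

The next compound to be measured is compound 4 `CCCS(=O)(=O)N1CCC2(CC1)OOC1(CCCCC1)OO2` and it departs from compound 3 in one place. The change is ethyl in place of hydrogen on a saturated chain carbon bound to a sulfonyl sulfur and it amounts to ethyl in place of hydrogen on a saturated chain carbon bound to a sulfonyl sulfur, so that methylsulfonyl becomes propylsulfonyl. Among the measured compounds shown here, no measured pair in the set shows a change of this kind, so the expectation has little to rest on. In this assay no step beyond the usual scatter is expected in either direction, given that compound 3 sits at > 100 ug/mL as a limit. The expected change is a number no higher from compound 3 to compound 4 (the limit leaves the size open) and it should stay within the scatter. For compound 4 the estimate is 100 ug/mL with an expected range of 50 ug/mL to 200 ug/mL and the assay will most likely report only a limit again.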

Compound 4, half-maximal cytotoxic concentration: > 100 ug/mL
Compound 4: only a limit was reported (the forecaster's own chance of this, stated with the estimate: 75%); the middle value sits exactly at the limit.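

In this assay no step can be read between compound 3 and compound 4, because both compounds return only a limit and not a number: the limit of > 100 ug/mL in this assay, at which 4 of the 4 values shown sit. The compounds shown leave open whether methylsulfonyl and propylsulfonyl, or any other difference among the four compounds, would separate them in toxicity in this test.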